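Removing a methyl from an aryl ether: compound 2 to 3

The source may hold more compounds than are shown below. What is called first, only, known or untested is meant among the compounds shown, and "the series" means these compounds.

Measured so far:
- compound 1 `CCOC(=O)C1=C(C)NC(=S)NC1c1cc(OC)c(O)c(OC)c1`: 25 ug/mL
- compound 2 `CCOC(=O)C1=C(C)NC(=S)NC1c1ccc(OC)cc1`: 3.2 ug/mL

Of the compounds shown here, two that share one core have been tested in a functional assay on NCI/ADR-RES cells (Homo sapiens) for inhibition, read by sulforhodamine B assay, with a stated time of 48 h; a lower number here means a stronger inhibitor of growth, a higher number a weaker inhibitor of growth. Compound 1 gives 25 ug/mL. Within the data shown here, compound 2 gives 3.2 ug/mL, the lowest of the two numbers, and the gap between compound 1 and compound 2 is beyond the usual scatter; only the values themselves are known, no single-point step connects the two.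

Compound 3 `CCOC(=O)C1=C(C)NC(=S)NC1c1ccc(O)cc1` differs from compound 2 in one place: hydrogen in place of methyl on an oxygen on an aromatic ring. Among the measured compounds shown here, nothing measured so far shows what this particular change does on its own, so the direction of the step is open. The only related observation is that compound 1, which carries a hydroxy among its ring substituents, sits well above compound 2 in this assay, but that compound also differs in two further places, so it cannot settle the question.

Compound 3 is therefore expected to land close to compound 2, with a small step of a 1.6-fold higher number from compound 2 to compound 3 (0.19 log units; within the scatter) toward a weaker inhibitor, and an estimated 5 ug/mL, ranging from 2 ug/mL to 15 ug/mL.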

Compound 3, concentration for 50% growth inhibition: 83.6 ug/mL
The estimate for compound 3 lay 17-fold (1.22 log units) below the measured number; measured number above the stated range.
By their numbers in this assay, from the lowest: compound 2; then compound 1; then compound 3.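

In this assay the change from methoxy to hydroxy on the aromatic ring is far from a minor edit: it brings a 26-fold higher number from compound 2 to compound 3 (1.42 log units; beyond the scatter) toward a weaker inhibitor of growth. Among these compounds, this is the first step in the set that isolates a single change, and it shows that this position is highly sensitive to what sits on the oxygen, with the loss of one methyl enough to move the number this far. No separate measurement on these compounds bears on the reason for so large a shift.

Going by these compounds, what remains open is whether the methyl is special or whether other groups on that oxygen would serve as well, for example an ethyl or a longer chain, or whether an amine or a fluorine could take the place of the methoxy altogether. Compound 1 also carries a hydroxy but differs from compound 3 in further places, so the effect of the added methoxy groups, and whether they change the outcome of this swap, stays unresolved with the compounds shown.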